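This account rests on a few compounds, and the source may have more. Where it says the series, first, only, none or still open, it means among the compounds named here.

Measured so far in an ADME assay on microsomes from liver (Homo sapiens) for metabolic stability, with a stated time of 10 min, tested at 0.5 uM; a lower number here means that less of the compound is left, a higher number that more of the compound is left (compound, then value):

- compound 1 `Cc1noc(C)c1[C@@H]1C[C@@](C)(c2ccc(F)cc2F)N=C(N)S1` gives 24%
- compound 2 `Cc1noc(C)c1[C@@H]1C[C@@](C)(c2ccc(F)cc2)N=C(N)S1` gives 73%
- compound 3 `Cc1onc(-c2ccc(F)cc2)c1[C@@H]1C[C@@](C)(c2ccc(F)cc2F)N=C(N)S1` gives 24%

Compound 1 stands level with compound 3, the two together at the low end of the three, while compound 2 lies well clear of both.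

Next is compound 4 `C[C@@]1(c2ccc(F)cc2F)C[C@@H](c2cncnc2)SC(N)=N1`, which differs from compound 1 as follows: pyrimidin-5-yl in place of 3,5-dimethyl-1,2-oxazol-4-yl on a saturated ring carbon. The change sits next to the ring sulfur.

Among the measured compounds shown here, two measured steps bear on it, both only loosely. The step of no change at the digits printed from compound 1 to compound 3 (within the scatter) altered the group that leaves here, with 4-fluorophenyl in place of methyl. The step of a number 49 percentage points higher from compound 1 to compound 2 (beyond the scatter) lies at another place, but it is the only one beyond the scatter, and it went upward. For the measured compounds named here, no measured step replaces the whole group, so a moderate rise is expected, with wide uncertainty.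

The estimated step is a number 16 percentage points higher from compound 1 to compound 4 (beyond the scatter), and it could still fall within the scatter. For compound 4 the expected value is 40%, with an estimated range from 20% to 70%.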

Compound 4, percent of the compound remaining: 90%
Beside the measured number, compound 4's estimate is 50 percentage points below it; measured number above the stated range.
By their numbers in this assay, from the lowest: compounds 1 and 3 (each within the scatter of the next); then compound 2; then compound 4.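

In this assay, the group on the saturated ring carbon next to the ring sulfur can move the read-out strongly: pyrimidin-5-yl in place of 3,5-dimethyl-1,2-oxazol-4-yl gives a number 66 percentage points higher from compound 1 to compound 4 (beyond the scatter). The earlier change within this group, 4-fluorophenyl in place of methyl, gave no change at the digits printed from compound 1 to compound 3 (within the scatter), so that step gave no sign of how much replacing the whole group could do. Compound 4 also keeps the aromatic fluoro whose replacement by hydrogen gave a number 49 percentage points higher from compound 1 to compound 2 (beyond the scatter), so retaining that fluoro does not by itself hold the number low, as compound 4 at 90% shows.

Going by these compounds, whether a pyridin-3-yl or a plain phenyl on this carbon would stand with compound 4, and what replacing that fluoro by hydrogen would do in compound 4, stays open. Nothing shown gives a reason for the rise.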